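A few compounds are considered here, and "the series" means these few. Any claim that something is new, unique, unknown or untested is made for them only; others in the source may bear on it.

Measured compounds:
- Compound 1, `Cn1c(-c2ccc(NC(=O)CCl)cc2)nc(-c2ccccc2)c1-c1ccccc1`, gives 15.1% in a functional assay on HT-29 cells (Homo sapiens) for cytotoxicity, read by MTT assay, with a stated time of 24 h, tested at 6.4 ug/mL; on this read-out higher numbers stand for a stronger effect at the one concentration tested and lower numbers for a weaker effect.
- Compound 2, `Cn1c(-c2ccc(NC(=O)CSc3nc4ccccc4s3)cc2)nc(-c2ccccc2)c1-c1ccccc1`, gives 36.8% in this assay.
- Compound 3, `Cn1c(-c2ccc(NC(=O)CSC3=NCCS3)cc2)nc(-c2ccccc2)c1-c1ccccc1`, gives 31% in this assay.

Compound 3 stands second highest of the three: compound 2 is a number 5.8 percentage points lower from compound 2 to compound 3 (within the scatter), a gap within the scatter, while compound 1 sits clearly lower, since the change from compound 1 to compound 3 gave a number 15.9 percentage points higher from compound 1 to compound 3 (beyond the scatter).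

Compound 4, `Cn1c(-c2ccc(NC(=O)CN3CCN(c4ccccc4)CC3)cc2)nc(-c2ccccc2)c1-c1ccccc1`, differs from compound 3 at the same position: a group of 12 heavy atoms (10 carbon, 2 nitrogen; one six-membered non-aromatic ring with 2 hetero atoms, one six-membered aromatic ring of carbon only) in place of a group of 6 heavy atoms (3 carbon, 1 nitrogen, 2 sulfur; one five-membered non-aromatic ring with 2 hetero atoms), on a saturated chain carbon bound to a carbonyl carbon.

For the measured compounds named here, two measured steps bear on that position. Replacing the chlorine of compound 1 gave a number 21.7 percentage points higher from compound 1 to compound 2 (beyond the scatter) and a number 15.9 percentage points higher from compound 1 to compound 3 (beyond the scatter), so a larger group at this position went along with a higher value in both cases. Between the two larger groups themselves, the step from compound 2 to compound 3 was a number 5.8 percentage points lower from compound 2 to compound 3 (within the scatter), within the scatter. Going by the values given here, no measured compound carries a group like the one entering in compound 4, so the direction of its step in this assay cannot be read from the data; the most that can be expected is a value near compound 3, with no step beyond the scatter. Compound 4 is therefore estimated at 30%, in the range 15% to 48%, which means an expected step of a number 1 percentage points lower from compound 3 to compound 4 (within the scatter).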

Compound 4, a percentage reported as activity, at one concentration (the size of the read-out at that concentration, not a potency): 46.5%
Compound 4: the middle estimate sits 16.5 percentage points below what was measured, and the stated range covers the measured number.
By their numbers in this assay, from the lowest: compound 1; then compounds 3, 2 and 4 (each within the scatter of the next, the first and the last beyond it).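

In this assay, the two earlier larger groups both hold sulfur, whereas the 4-phenylpiperazin-1-yl group holds none, and putting it in place of chloro still gave a number 31.4 percentage points higher from compound 1 to compound 4 (beyond the scatter). Against the groups that carry sulfur the result divides: the change gave a number 15.5 percentage points higher from compound 3 to compound 4 (beyond the scatter), but a number 9.7 percentage points higher from compound 2 to compound 4 (within the scatter), so this group stands apart from the five-membered non-aromatic ring and not from (1,3-benzothiazol-2-yl)sulfanyl. Nothing measured here gives a cause for these steps.

From the compounds shown here alone, it remains open whether the step belongs to the piperazine ring or to its phenyl group. A piperazine without the phenyl, a 4-methylpiperazin-1-yl group or a morpholine ring at this place would help separate the two.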